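The source may hold more compounds than are shown below. What is called first, only, known or untested is meant among the compounds shown, and "the series" means these compounds.

Three compounds have so far been run in an assay on isolated protein for inhibition of malate dehydrogenase, mitochondrial (Sus scrofa), with stated times of 45 min and 30 min; on this read-out lower numbers stand for stronger inhibition and higher numbers for weaker inhibition. Compound 1 `O=S(=O)(Nc1ccc2oc(-c3ccccc3)nc2c1)c1cccc(C(F)(F)F)c1` is reported only as a limit of the assay, not a number: in this assay compound 1 gives > 63000 nM. Compound 2 `Cc1cccc(S(=O)(=O)Nc2ccc3oc(-c4ccccc4)nc3c2)c1` likewise returns only a limit, > 63000 nM. Compound 3 `Cc1ccccc1S(=O)(=O)Nc1ccc(-c2nc3ccccc3o2)cc1` also stands at a limit, > 63000 nM. The change from compound 2 to compound 1 is trifluoromethyl in place of methyl on an aromatic carbon; the step that the two limits leave unreadable from compound 2 to compound 1 cannot be sized, since both ends are limits. The difference between the cores of compound 2 and compound 3 is not broken down here. Compound 4 `O=S(=O)(Nc1ccc(-c2nc3ccccc3o2)cc1)c1ccccc1C(F)(F)F` has not been measured; it differs from compound 3 by trifluoromethyl in place of methyl on an aromatic carbon, the same kind of change as from compound 2 to compound 1, though the place is not the same: ortho to a large group here, meta to a large group there. Because every value sits at the limit of > 63000 nM in this assay, at which 3 of the 3 values shown sit, no readable step exists to scale an expectation. Compound 4 is therefore expected to remain a limit, estimated at 100000 nM with a range of 40000 nM to 300000 nM. The estimated step that the limit leaves unreadable from compound 3 to compound 4 is expected to be unreadable in the same way.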

Compound 4, half-maximal inhibitory concentration: > 63000 nM
Compound 4: only a limit was reported; the forecaster's own chance of this, stated with the estimate: 85%; the middle value is on the limit's open side.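

Compound 3 and compound 4 both stand at a limit of the assay, and no step can be read between them in this assay. The compounds shown leave open whether any member of the series gives a readable value, and how large the change from methyl to trifluoromethyl is: the limit of > 63000 nM in this assay, at which 4 of the 4 values shown sit.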